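Selenium for Sulfur on Two Diacyl Isothiourea Cores

The source may hold more compounds than are shown below. What is called first, only, known or untested is meant among the compounds shown, and "the series" means these compounds.

Of the compounds shown here, three have so far been measured in a functional assay on PC-3 cells (Homo sapiens) for cytotoxicity, read by MTT assay, with a stated time of 72 h; a lower number here means a stronger inhibitor of growth, a higher number a weaker inhibitor of growth. Compound 1 `CS/C(=N\C(=O)c1cc2ccccc2s1)NC(=O)c1cc2ccccc2s1` gives 8580 nM, the lowest of the three numbers. Compound 2 `CS/C(=N\C(=O)c1ccco1)NC(=O)c1ccco1` gives 56200 nM, and compound 3 `O=C(/N=C(/NC(=O)c1ccco1)[Se]Cc1ccccc1)c1ccco1` gives 30500 nM. Compound 1 and compound 2 share the same central arrangement but carry different aromatic acyl groups on it; the difference between the two cores is not broken down here.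

Compound 3 arises from compound 2 through a single exchange: a group of 8 heavy atoms (7 carbon, 1 selenium; one six-membered aromatic ring of carbon only) in place of a group of 2 heavy atoms (1 carbon, 1 sulfur; no ring), on a carbon with a double bond to nitrogen This exchange produced a 1.8-fold lower number from compound 2 to compound 3 (0.27 log units; within the scatter).

Compound 4 `O=C(/N=C(/NC(=O)c1cc2ccccc2s1)[Se]Cc1ccccc1)c1cc2ccccc2s1` has not yet been measured. It arises from compound 1 through the identical exchange: a group of 8 heavy atoms (7 carbon, 1 selenium; one six-membered aromatic ring of carbon only) in place of a group of 2 heavy atoms (1 carbon, 1 sulfur; no ring), on a carbon with a double bond to nitrogen The place of the change is described in the same words for both pairs, so it is the same change, carried from the core of compound 2 onto the core of compound 1.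

Going by the values given here, the only guide to what the change will do on the core of compound 1 is the one earlier instance. Because that instance gave a 1.8-fold lower number from compound 2 to compound 3 (0.27 log units; within the scatter) on the core of compound 2, a step of similar size and direction is expected here, with the usual caution that a single step of that size cannot be told apart from repeat scatter. Starting from compound 1, which gives 8580 nM, the expected result for compound 4 is a 1.7-fold lower number from compound 1 to compound 4 (0.23 log units; within the scatter) in this assay. Compound 4 is thus estimated at 5000 nM, with the expected range running from 2000 nM to 12000 nM.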

Compound 4, concentration for 50% growth inhibition: 30500 nM
For compound 4 the middle estimate is 6.1-fold (0.79 log units) below the measured one; the measured number lies above the stated range.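

On the core of compound 1, in this assay, putting the selenium-bearing group with its six-membered aromatic ring in place of methylsulfanyl gave a 3.6-fold higher number from compound 1 to compound 4 (0.55 log units; beyond the scatter), a modest step that stands clear of repeat scatter. Set beside the only other instance of this exchange, the result shows that, in these two pairs, the effect of the change did not carry from one core to the other: the same change on two cores in this assay, a 1.8-fold lower number (0.27 log units; within the scatter) from compound 2 to compound 3 and a 3.6-fold higher number (0.55 log units; beyond the scatter) from compound 1 to compound 4, 6.6-fold (0.82 log units) apart, beyond the scatter of two such steps It does not show why the two cores part, and with only two pairs it gives no rule for any further core; nor does it show which part of the exchange matters, since sulfur gives way to selenium and the aromatic ring enters in the same step.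

The compounds shown leave open how a methyl group on selenium, or the same ring-bearing group on sulfur, would stand on either core, and such a pair would separate the element from the ring. They also leave open how a longer chain or an amine at this carbon with a double bond to nitrogen would behave, and whether other aromatic acyl groups would follow compound 1 or compound 2.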